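The source may report more compounds than this note shows. Statements on the series, on what has been measured and on what is new or still open speak of the compounds shown alone.

Working notes on the amine side chain series. In a functional assay on HT-29 cells (Homo sapiens) for inhibition, read by MTT assay, with a stated time of 72 h (a higher number here means a weaker inhibitor, a lower number a stronger inhibitor), compound 1 `CCCNC(=C\C(=O)/C=C/c1ccc(O)c(OC)c1)/C=C/c1ccc(O)c(OC)c1` gives 22700 nM and compound 3 `COc1cc(/C=C/C(=O)/C=C(/C=C/c2ccc(O)c(OC)c2)NCC(C)C)ccc1O` gives 24500 nM, the two level within the scatter, so compound 1 is the nearest neighbour of compound 3. Compound 2 `CCC(C)NC(=C\C(=O)/C=C/c1ccc(O)c(OC)c1)/C=C/c1ccc(O)c(OC)c1` is reported as > 25000 nM, a limit of the assay and not a number. The change to compound 4 `CCCCNC(=C\C(=O)/C=C/c1ccc(O)c(OC)c1)/C=C/c1ccc(O)c(OC)c1` is propyl in place of isopropyl on a saturated chain carbon bound to an amine nitrogen, which reads isobutyl to butyl one bond further out. The measured chain changes are small: an at least 1.1-fold higher number from compound 1 to compound 2 (0.04 log units; that floor lies within the scatter), a 1.1-fold higher number from compound 1 to compound 3 (0.03 log units; within the scatter) and an at least 1.0-fold lower number from compound 2 to compound 3 (0.00 log units; that floor lies within the scatter). The last and the first are only floors. No shift beyond the scatter is therefore expected in this assay. The expected step is a 1.1-fold lower number from compound 3 to compound 4 (0.05 log units; within the scatter). Compound 4 is estimated at 22000 nM, with an expected range of 12000 nM to 32000 nM.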

Compound 4, half-maximal inhibitory concentration: 19700 nM
Estimate against measurement, compound 4: 1.1-fold (0.05 log units) above, and the stated range covers the measured number.
By their numbers in this assay, from the lowest: compounds 4, 1 and 3 (each within the scatter of the next). At a limit, above all of these: compound 2.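

In this assay, the unbranched butyl chain on the amine nitrogen sits level with both its branched isomer and the shorter chain: a 1.2-fold lower number from compound 3 to compound 4 (0.09 log units; within the scatter), and a 1.2-fold lower number from compound 1 to compound 4 (0.06 log units; within the scatter). Removing the branch from sec-butyl also gives only a floor, an at least 1.2-fold lower number from compound 2 to compound 4 (0.10 log units; that floor lies within the scatter), so no shift beyond the scatter is shown at this position. The value of compound 2 is a limit and not a number: the limit of > 25000 nM in this assay, at which 1 of the 4 values shown sits.

Still open, going by these compounds, is whether a longer chain, such as octyl, or a carboxylic acid at the chain end would move the number beyond the scatter.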